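Bromo on the Benzoyl Ring of Compound 2

The source may hold more compounds than are shown below. What is called first, only, known or untested is meant among the compounds shown, and "the series" means these compounds.

Three measured compounds share one core and differ only in the aromatic group carried by the saturated carbon bound to the ring nitrogen. Compound 1 `COc1cccc(CN2Cc3c(NC(=O)c4ccccc4)n[nH]c3C2(C)C)c1` carries a 3-methoxyphenyl there and gives 1120 nM in an assay on Sf21 cells for inhibition of high affinity nerve growth factor receptor (Homo sapiens), read by HTRF, with a stated time of 30 min, in the presence of a further agent that is not named here; a higher number here means a weaker inhibitor, a lower number a stronger inhibitor. Compound 2 `CC1(C)c2[nH]nc(NC(=O)c3ccccc3)c2CN1Cc1cc(F)cc(F)c1` carries a 3,5-difluorophenyl and gives 190 nM in this assay, while compound 3 `CC1(C)c2[nH]nc(NC(=O)c3ccccc3)c2CN1Cc1ccc(F)c(F)c1` carries a 3,4-difluorophenyl and gives 680 nM in this assay. Compound 2 stands lowest of the three: a 5.9-fold lower number from compound 1 to compound 2 (0.77 log units; beyond the scatter) and a 3.6-fold higher number from compound 2 to compound 3 (0.55 log units; beyond the scatter), whereas a 1.6-fold lower number from compound 1 to compound 3 (0.22 log units; within the scatter).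

Compound 4 `CC1(C)c2[nH]nc(NC(=O)c3ccc(Br)cc3)c2CN1Cc1cc(F)cc(F)c1` keeps the 3,5-difluorophenyl of compound 2 and changes the other end of the molecule, the benzoyl group on the amide: bromo in place of hydrogen on an aromatic carbon. Going by the values given here, none of the three measured steps touches the benzoyl ring; all of them swap the group on the ring nitrogen, so no measured step bears directly on this change. With nothing in the data pointing either way, the expectation is no step beyond the scatter, so the estimated step is no change at the digits printed from compound 2 to compound 4 (within the scatter). Compound 4 is therefore expected to give about 190 nM in this assay, within a range from 60 nM to 600 nM.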

Compound 4, half-maximal inhibitory concentration: 710 nM
Compound 4: the middle estimate sits 3.7-fold (0.57 log units) below what was measured; the whole stated range lies below it.
By their numbers in this assay, from the lowest: compound 2; then compounds 3, 4 and 1 (each within the scatter of the next).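

The benzoyl ring, untouched by every earlier step, now proves to matter: in this assay a single bromo on an aromatic carbon, para to a large group, gives a 3.7-fold higher number from compound 2 to compound 4 (0.57 log units; beyond the scatter) and so weakens inhibition by more than the usual scatter. Going by these compounds alone, both ends of the molecule therefore respond to change, the group on the ring nitrogen in the earlier compounds and now the benzoyl ring, where the unsubstituted phenyl of compound 2 gives the lower number of the pair. No measurement shown here explains why this bromo raises the number.

This single comparison cannot separate an effect of bromo itself from one shared by any group at this place, so a fluoro, a methoxy or an amine on the same carbon would be the informative next comparison. Also open, as far as these compounds go, are how bromo behaves on the other carbons of the benzoyl ring, and whether the same step appears when the ring nitrogen carries the 3-methoxyphenyl of compound 1 or the 3,4-difluorophenyl of compound 3.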